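Fluoro on the phenyl of compound 3

The compounds below may be only part of what the source reports. "The series", "measured", "known", "first", "only" and "open" are said of these compounds alone.

Compound 3 `CC(C)(C)n1ncc(OCc2nnc(-c3ccccc3)o2)c(Cl)c1=O` gives 12.2 ug/mL in a functional assay on the whole organism for inhibition, with Mythimna separata as the target, with a stated time of 5 days (on this read-out higher numbers stand for an effect only at larger amounts of compound and lower numbers for an effect already at smaller amounts), the only number shown in the series. Compound 1 `Cc1nnc(COc2cnn(C(C)(C)C)c(=O)c2Cl)o1` gives > 300 ug/mL in this assay, which is a limit and not a number. Compound 2 `Cc1cc(C)cc(-c2nnc(COc3cnn(C(C)(C)C)c(=O)c3Cl)o2)c1` likewise gives > 300 ug/mL, again a limit. The measured steps of an at least 24-fold lower number from compound 1 to compound 3 (1.39 log units; beyond the scatter) and an at least 24-fold lower number from compound 2 to compound 3 (1.39 log units; beyond the scatter) are large, with the limit of > 300 ug/mL in this assay, at which 2 of the 3 values shown sit, setting their floor. Compound 4 `CC(C)(C)n1ncc(OCc2nnc(-c3ccccc3F)o2)c(Cl)c1=O` differs from compound 3 by fluoro in place of hydrogen on an aromatic carbon. No measured step concerns adding a substituent to the phenyl of compound 3; the steps shown concern exchange of the whole group. Compound 4 is therefore expected to give 10 ug/mL in this assay, within 3 ug/mL to 40 ug/mL, an estimated step of a 1.2-fold lower number from compound 3 to compound 4 (0.09 log units; within the scatter) that stays within the scatter.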

Compound 4, half-maximal effective concentration: 16.8 ug/mL
Compound 4: middle estimate off by 1.7-fold (0.23 log units), on the low side, and the stated range covers the measured number.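

Fluoro ortho to a large group on the phenyl leaves the read-out of this assay unmoved, with a 1.4-fold higher number from compound 3 to compound 4 (0.14 log units; within the scatter), so this position accepts one fluorine where the earlier compounds showed only exchange of the whole group. The large separation from the inactive compounds carries over to the 2-fluorophenyl, with an at least 17-fold lower number from compound 2 to compound 4 (1.25 log units; beyond the scatter) and an at least 17-fold lower number from compound 1 to compound 4 (1.25 log units; beyond the scatter), though these sizes are only floors because of the assay limit: the limit of > 300 ug/mL in this assay, at which 2 of the 4 values shown sit.

As far as these compounds go, what a bulkier substituent such as trifluoromethyl or methoxy, or an amine, would do at this position remains open.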